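The compounds below may be only part of what the source reports. "The series", "measured", "known", "first", "only" and "open" are said of these compounds alone.

Measured so far in an ADME assay on microsomes from liver (Homo sapiens) for metabolic stability, with a stated time of 10 min, tested at 0.5 uM; a lower number here means that less of the compound is left, a higher number that more of the compound is left:
- compound 1 `C[C@@H](NCc1ccc(Cl)cc1)[C@H]1CC[C@@H](c2ccnc3ccc(F)cc32)CC1`: 34%
- compound 2 `C[C@@H](NS(=O)(=O)c1ccc(Cl)cc1)[C@H]1CC[C@@H](c2ccnc3ccc(F)cc32)CC1`: 29%

Compound 2, at 29%, stands within the scatter of compound 1, at 34%. Compound 3 `C[C@@H](NC(=O)Nc1ccc(Cl)cc1)[C@H]1CC[C@@H](c2ccnc3ccc(F)cc32)CC1` has (4-chlorophenyl)carbamoyl in place of (4-chlorophenyl)sulfonyl on an amine nitrogen. Within the data shown here, one measured step bears on this, an exchange on the same nitrogen: a number 5 percentage points lower from compound 1 to compound 2 (within the scatter). Among the measured compounds shown here, with only that step as a guide, no change beyond the scatter is expected in this assay. The expected step is a number 1 percentage points higher from compound 2 to compound 3 (within the scatter). Compound 3 is estimated at 30%, with an expected range of 15% to 50%.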

Compound 3, percent of the compound remaining: 52%
Compound 3: the middle estimate sits 22 percentage points below what was measured; the measured number lies above the stated range.
By their numbers in this assay, from the lowest: compounds 2 and 1 (each within the scatter of the next); then compound 3.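

In this assay this amine nitrogen proves sensitive to the group it carries, which the first exchange there, staying within the scatter, did not show: (4-chlorophenyl)carbamoyl gives a number 23 percentage points higher from compound 2 to compound 3 (beyond the scatter), and a number 18 percentage points higher from compound 1 to compound 3 (beyond the scatter). Of the three groups, only (4-chlorophenyl)carbamoyl separates from the others, while the (4-chlorophenyl)sulfonyl and 4-chlorobenzyl compounds remain within the scatter of each other. Nothing available explains why this group stands apart.

Going by these compounds, whether a plain amide, with a methylene in place of the urea nitrogen attached to the aryl ring, keeps this step remains open. So does whether the step survives with 4-methoxyphenyl in place of 4-chlorophenyl.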